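Removing a fluoro substituent on a biphenyl sulfonamide agonist

The compounds below may be only part of what the source reports. "The series", "measured", "known", "first", "only" and "open" are said of these compounds alone.

Compound 1 `COc1ccc(N2C[C@@H](C)N[C@@H](C)C2)cc1NS(=O)(=O)c1ccc(-c2ccccc2)cc1`: 1
Compound 2 `COc1ccc(F)c(-c2ccc(S(=O)(=O)Nc3cc(N4C[C@@H](C)N[C@@H](C)C4)ccc3OC)cc2)c1`: 1.2

In a functional assay for agonist activity at growth hormone secretagogue receptor type 1 (Homo sapiens), read by FLIPR (on this read-out lower numbers stand for smaller maximal responses and higher numbers for larger maximal responses), compound 2 gives 1.2, the highest of the two numbers measured; its nearest neighbour is compound 1, whose value lies a step below, and that step is beyond the scatter. Compound 3 `COc1cccc(-c2ccc(S(=O)(=O)Nc3cc(N4C[C@@H](C)N[C@@H](C)C4)ccc3OC)cc2)c1` differs from compound 2 by hydrogen in place of fluoro on an aromatic carbon. Within the data shown here, the one measured step that bears on it is a number 0.20 higher from compound 1 to compound 2 (beyond the scatter), where a phenyl became a 2-fluoro-5-methoxyphenyl; that change brought in both the fluoro and the methoxy at once, so the share of the fluoro alone cannot be separated from it. Compound 3 keeps the methoxy and loses only the fluoro, so a small fall toward the value of compound 1 is expected, likely within the scatter: a number 0.10 lower from compound 2 to compound 3 (within the scatter). Compound 3 is therefore estimated to give 1.1 in this assay, in the range 0.9 to 1.3.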

Compound 3, intrinsic activity: the largest response reached, as a fraction of the reference agonist's: 1
Compound 3: middle estimate off by 0.10, on the high side, within the range that was stated.
By their numbers in this assay, from the lowest: compounds 1 and 3 (each within the scatter of the next); then compound 2.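

In this assay the fluoro alone, on an aromatic carbon ortho to a large group and para to a methoxy group, carries a step beyond the scatter: its replacement by hydrogen gives a number 0.20 lower from compound 2 to compound 3 (beyond the scatter). The methoxy alone, set on the phenyl of compound 1, gives no change at the digits printed from compound 1 to compound 3 (within the scatter), so the earlier rise, a number 0.20 higher from compound 1 to compound 2 (beyond the scatter), appears here only where the fluoro stands together with the methoxy. Nothing measured here accounts for the effect of the fluoro at this position.

The compounds shown leave open whether a 2-fluorophenyl without the methoxy would reach the same maximal response as compound 2, which would show whether the fluoro depends on the methoxy. They also leave open whether chloro or methyl at the same carbon would match the fluoro.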